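The compounds below may be only part of what the source reports. "The series", "measured", "known", "first", "only" and "open" are said of these compounds alone.

Compound 1 `NC(=S)N1N=C(c2ccc(N3CCCCC3)cc2)CC1c1ccc(Cl)cc1` gives in a functional assay on A-375 cells (Homo sapiens) for antiproliferative activity, read by MTT assay, with a stated time of 72 h (on this read-out lower numbers stand for stronger inhibition and higher numbers for weaker inhibition), the value > 100000 nM, which is a limit of the assay and not a number.
Compound 2 `Clc1ccc(C2CC(c3ccc(N4CCCCC4)cc3)=NN2c2nc(-c3ccc(Br)cc3)cs2)cc1` gives in this assay the value > 100000 nM, again a limit of the assay rather than a number.

On the numbers shown, compound 2 stands only at a limit, and the one further value shown is a limit as well, both sitting at the limit of > 100000 nM in this assay, at which 2 of the 2 values shown sit. For the measured compounds named here, the single step between measured compounds, a step that the two limits leave unreadable from compound 1 to compound 2, therefore has no readable size and no readable direction. Compound 3 `CS(=O)(=O)c1ccc(-c2csc(N3N=C(c4ccc(N5CCCCC5)cc4)CC3c3ccc(Cl)cc3)n2)cc1` is not yet measured. It differs from compound 2 by methylsulfonyl in place of bromo on an aromatic carbon. Going by the values given here, no measured step bears on this change: the only step available, a step that the two limits leave unreadable from compound 1 to compound 2, offers nothing to compare against, and nothing in the data points to any effect beyond the scatter. Compound 3 is thus expected to stay at the limit, estimated at 100000 nM, within 30000 nM to 300000 nM. The step expected here is a number no higher from compound 2 to compound 3 (the limit leaves the size open), which in practice means the assay is again likely to report only a limit.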

Compound 3, half-maximal inhibitory concentration: > 100000 nM
Compound 3 ended at the assay's limit; the forecaster's own chance of this, stated with the estimate: 70%; the middle value lies on the limit itself.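

No size or direction can be read for the change from compound 2 to compound 3, methylsulfonyl in place of bromo, since neither compound gives a number in this assay and each stands only at a limit: the limit of > 100000 nM in this assay, at which 3 of the 3 values shown sit.

The compounds shown leave open what true value any of them has, and whether any of these group changes affects antiproliferative activity.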